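A Thioether Side Chain Swap on a Shared Dicyanopyridine Core

The source may hold more compounds than are shown below. What is called first, only, known or untested is meant among the compounds shown, and "the series" means these compounds.

Compound 1 `N#Cc1c(N)nc(SCc2cccc(C(N)=O)c2)c(C#N)c1-c1ccc(OCC2CC2)cc1`: 1%
Compound 2 `N#Cc1c(N)nc(SCc2nc3ccccc3[nH]2)c(C#N)c1-c1ccc(OCC2CC2)cc1`: 1%
Compound 3 `N#Cc1c(N)nc(SCC2=NCCN2)c(C#N)c1-c1ccc(OCC2CC2)cc1`: 6%

Three compounds share a core and differ only in the group carried on a saturated chain carbon bound to a sulfur. In an assay on CHO cells for displacement of a labelled ligand from adenosine receptor A3 (Homo sapiens), read by scintillation counting, with a stated time of 120 min, tested at 1 uM (on this read-out higher numbers stand for more inhibition at the one concentration tested (going by the name of the read-out) and lower numbers for less inhibition), compound 1 gives 1%, compound 2 gives 1% and compound 3 gives 6%. Compound 3 therefore stands alongside the other two: the steps of a number 5 percentage points higher from compound 1 to compound 3 (within the scatter) and a number 5 percentage points higher from compound 2 to compound 3 (within the scatter) both remain within the scatter, and the step of no change at the digits printed from compound 1 to compound 2 (within the scatter) shows the same picture.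

Compound 4 `CNC(=O)CSc1nc(N)c(C#N)c(-c2ccc(OCC3CC3)cc2)c1C#N` continues this series. Its change from compound 3 is a group of 4 heavy atoms (2 carbon, 1 nitrogen, 1 oxygen; no ring) in place of a group of 5 heavy atoms (3 carbon, 2 nitrogen; one five-membered non-aromatic ring with 2 hetero atoms), on a saturated chain carbon bound to a sulfur. Going by the values given here, the steps that bear on it are those from compound 1 and compound 2 to compound 3, each within the scatter, so no step beyond the scatter is expected in this assay; the expected step is a number 3 percentage points lower from compound 3 to compound 4 (within the scatter). Compound 4 is therefore estimated to give 3%, in the range -5% to 12%.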

Compound 4, a percentage reported as inhibition, at one concentration (the size of the read-out at that concentration, not a potency): 3%
Beside the measured number, compound 4's estimate shows no gap at the digits printed; measured number inside the range.
By their numbers in this assay, from the lowest: compounds 1, 2, 4 and 3 (each within the scatter of the next).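

In this assay the ring-free methylcarbamoyl group stands on the saturated chain carbon bound to a sulfur, and the steps of a number 3 percentage points lower from compound 3 to compound 4 (within the scatter) and a number 2 percentage points higher from compound 2 to compound 4 (within the scatter) and a number 2 percentage points higher from compound 1 to compound 4 (within the scatter) add no difference beyond the scatter. Every earlier group at this place carried a ring, so compound 4 extends the same picture to a group with no ring at all. No measurement given here accounts for this picture.

The compounds shown leave open whether a carboxylic acid, a primary amine or a longer alkyl chain on this carbon would give a number beyond the scatter of these four. They also leave open whether any group at this place changes the reading when the rest of the shared core stays the same.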